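This account rests on a few compounds, and the source may have more. Where it says the series, first, only, none or still open, it means among the compounds named here.

Among the compounds with values here, compound 1 `O=c1c(-c2nn[nH]n2)c[nH]c2ccccc12` is the starting point, and in a functional assay on the whole organism (strain Sprague-Dawley) for inhibition, with Rattus norvegicus as the target (a higher number here means that more compound is needed for the effect, a lower number that less compound is needed), compound 1 gives 1.25 mg/kg, the only definite number in this set. Compound 2 `CCc1ccc2[nH]cc(-c3nn[nH]n3)c(=O)c2c1` carries an ethyl in place of hydrogen on an aromatic carbon of the shared core. In this assay compound 2 gives < 5 mg/kg, and this is a limit of the assay, not a number. Behind it stands (the limit of < 5 mg/kg in this assay, at which 1 of the 2 values shown sits), at which compound 2 sits. The step that the limit leaves unreadable from compound 1 to compound 2 therefore has no readable size, neither in direction nor in magnitude.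

Compound 3 `O=c1c(-c2nn[nH]n2)c[nH]c2c(C(F)(F)F)cccc12` differs from compound 1 by trifluoromethyl in place of hydrogen on an aromatic carbon. Within the data shown here, the only measured change that bears on it, a step that the limit leaves unreadable from compound 1 to compound 2, is also a swap of hydrogen for a carbon group on an aromatic carbon, yet it is unreadable, so it offers no direction for the trifluoromethyl. No step beyond the scatter can be expected on that basis, and the step of a 1.2-fold higher number from compound 1 to compound 3 (0.08 log units; within the scatter) is estimated to stay close to zero. Compound 3 is therefore estimated at 1.5 mg/kg, within a range from 0.5 mg/kg to 5 mg/kg.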

Compound 3, minimum effective dose: 0.156 mg/kg
The estimate for compound 3 lay 9.6-fold (0.98 log units) above the measured number; measured number outside the range, below it.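

In this assay, trifluoromethyl in place of hydrogen on this aromatic carbon, ortho to a fused ring, gives an 8.0-fold lower number from compound 1 to compound 3 (0.90 log units; beyond the scatter), so less compound is needed for the effect. This is the first step on the shared core whose size and direction can be read, as the earlier step to compound 2, with its ethyl, cannot be read, compound 2 being held at a limit and not a number: the limit of < 5 mg/kg in this assay, at which 1 of the 3 values shown sits.

The new step therefore shows that this aromatic carbon can carry a group of 4 heavy atoms in place of hydrogen and that the whole-organism effect then needs less compound, though nothing shown explains why.

The compounds shown do not tell whether a methyl, a chlorine or an amine on this same carbon would give a step of similar size, so the gain cannot yet be tied to trifluoromethyl rather than to any group placed there. They also leave open whether trifluoromethyl on the other aromatic carbons of the shared core would give such a step.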